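A few compounds are considered here, and "the series" means these few. Any claim that something is new, unique, unknown or untested is made for them only; others in the source may bear on it.

- Compound 1 `CC(=O)NCCSCC(=O)c1c(C)[n+]([O-])c2ccccc2[n+]1[O-]`: "not determined" (no result reported)
- Compound 2 `Cc1c(C(=O)CSCCNC(=O)c2ccncc2)[n+]([O-])c2ccccc2[n+]1[O-]`: 50 ug/mL

Within the data shown here, in an ADME assay on Vero cells (Chlorocebus sabaeus) for cytotoxicity, read by MTT assay, with a stated time of 72 h (a lower number here means that less compound is tolerated, a higher number that more compound is tolerated), compound 2 gives 50 ug/mL and this is the only number, as compound 1 has no reported result. It therefore cannot be ranked against any other compound. Compound 3 `Cc1c(C(=O)CSCCNC(=O)c2ccc3ccccc3c2)[n+]([O-])c2ccccc2[n+]1[O-]` differs from compound 2 in one place, with naphthalen-2-yl in place of pyridin-4-yl on a carbonyl carbon. Among the measured compounds shown here, no measured step exists to show what such a change does here, so the expectation rests only on compound 2 at 50 ug/mL and on the structural change itself. A moderate downward move in this assay is expected, estimated as a 2.5-fold lower number from compound 2 to compound 3 (0.40 log units; beyond the scatter), though with wide uncertainty. For compound 3 the estimated value is 20 ug/mL (expected range 6 ug/mL to 60 ug/mL).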

Compound 3, half-maximal cytotoxic concentration: > 100 ug/mL
Compound 3 gave a limit, no number (the forecaster's own chance of this, stated with the estimate: 10%); middle value at least 5.0-fold (0.69 log units) from the limit.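

In this assay compound 3 gives > 100 ug/mL as a limit of the assay, not as a number. On the carbonyl carbon whose other neighbour is the amide-type nitrogen, naphthalen-2-yl in place of pyridin-4-yl gives an at least 2.0-fold higher number from compound 2 to compound 3 (0.30 log units; that floor lies within the scatter) rather than a lower one, so the larger all-carbon group does not reduce what is tolerated in this pair. Only a floor can be stated for this step, and its true size stays unknown, because compound 3 sits at the limit of the assay: the limit of > 100 ug/mL in this assay, at which 1 of the 3 values shown sits.

The compounds shown leave open how the number would move with a plain phenyl or a saturated amine such as piperidin-4-yl on the same carbonyl carbon. Also open, going by these compounds, is whether a carboxylic acid on the naphthalen-2-yl group would keep compound 3's tolerance.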